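Thiophene for furan on the core of compound 1

The compounds below may be only part of what the source reports. "The series", "measured", "known", "first", "only" and "open" are said of these compounds alone.

Measured so far:
compound 1 `Nc1nc(NCc2cccs2)nc2sc(-c3ccco3)nc12`, 12.5 nM
compound 2 `Nc1nc(NCc2ccsc2)nc2sc(-c3ccco3)nc12`, 8.12 nM

Of the compounds shown here, two have been measured in an assay on CHO cells for displacement of a labelled ligand from adenosine receptor A1 (Homo sapiens), read by scintillation counting, with a stated time of 90 min; on this read-out higher numbers stand for weaker inhibition and lower numbers for stronger inhibition. Compound 1 gives 12.5 nM. Compound 2 differs from compound 1 by thiophen-3-yl in place of thiophen-2-yl on a saturated chain carbon bound to a nitrogen on an aromatic ring. Compound 2 gives 8.12 nM; the step of a 1.5-fold lower number from compound 1 to compound 2 (0.19 log units; within the scatter) is within the scatter, so compound 1 stands level with compound 2 on the numbers shown.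

Compound 3 `Nc1nc(NCc2cccs2)nc2sc(-c3cccs3)nc12` is not yet measured. It differs from compound 1 by thiophen-2-yl in place of furan-2-yl on an aromatic carbon. For the measured compounds named here, no measured step touches this position of the shared core; the single step available, a 1.5-fold lower number from compound 1 to compound 2 (0.19 log units; within the scatter), concerns the other substituent and was within the scatter. With nothing to argue for a change, compound 3 is expected to give about 12 nM in this assay, with a range of 4 nM to 40 nM, that is, an estimated step of a 1.0-fold lower number from compound 1 to compound 3 (0.02 log units; within the scatter) and none beyond the scatter.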

Compound 3, inhibition constant: 73 nM
Beside the measured number, compound 3's estimate is 6.1-fold (0.78 log units) below it; measured number above the stated range.
By their numbers in this assay, from the lowest: compounds 2 and 1 (each within the scatter of the next); then compound 3.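

In this assay, for the compounds shown here, this position on the shared core responds to the exchange of one ring for another: thiophen-2-yl in place of furan-2-yl on this aromatic carbon gives a 5.8-fold higher number from compound 1 to compound 3 (0.77 log units; beyond the scatter), the first step here beyond the scatter. The two groups have the same counts of heavy atoms, hydrogen-bond donors and acceptors, and differ in one ring atom, sulfur for oxygen, yet this step is larger than a 1.5-fold lower number from compound 1 to compound 2 (0.19 log units; within the scatter), which concerned the other substituent. Nothing among the data shown accounts for the loss on moving to sulfur.

As far as these compounds go, it remains open whether the same exchange would cost as much when the chain carries thiophen-3-yl instead of thiophen-2-yl. From the compounds shown here alone, it is also open how this position would respond to a phenyl ring, a methyl group or an amine.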